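This account rests on a few compounds, and the source may have more. Where it says the series, first, only, none or still open, it means among the compounds named here.

In a functional assay on HeLa cells (Homo sapiens) for antiproliferative activity, read by sulforhodamine B assay, with a stated time of 48 h (a higher number here means a weaker inhibitor, a lower number a stronger inhibitor), compound 1 `CCc1ccc(N(C)c2ncnc3occ(C)c23)cc1` gives 121 nM and compound 2 `CCCCN(c1ccc(OC)cc1)c1ncnc2occ(C)c12` gives 111 nM, so compound 2 stands level with compound 1, within the usual scatter of repeated measurements. Compound 3 `COc1ccc(N(C)c2ncnc3occ(C)c23)cc1` differs from compound 2 in one place, hydrogen in place of propyl on a saturated chain carbon bound to a nitrogen on an aromatic ring, which turns butyl into methyl. Within the data shown here, no measured pair shows this change alone, so the forecast is uncertain. A moderate step towards a stronger inhibitor, beyond the scatter, is expected in this assay. The estimated change is a 3.7-fold lower number from compound 2 to compound 3 (0.57 log units; beyond the scatter). For compound 3 the expected value is 30 nM, within an estimated range of 8 nM to 110 nM.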

Compound 3, half-maximal inhibitory concentration: 9.5 nM
Estimate against measurement, compound 3: 3.2-fold (0.50 log units) above; the range from low to high includes it.
By their numbers in this assay, from the lowest: compound 3; then compounds 2 and 1 (each within the scatter of the next).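

In this assay, the step of a 12-fold lower number from compound 2 to compound 3 (1.07 log units; beyond the scatter) comes from shortening butyl to methyl with the methoxy kept, so the length of this chain matters in the methoxy series. The step of a 13-fold lower number from compound 1 to compound 3 (1.11 log units; beyond the scatter) comes from methoxy in place of ethyl on an aromatic carbon with the methyl kept, so this ring group matters as well. No measurement here bears on the reason for either step. Still open, from the compounds shown here alone, is how a propyl chain in place of that butyl would fare, and whether a hydroxyl or an amine on that aromatic carbon would match methoxy.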